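The source may hold more compounds than are shown below. What is called first, only, known or untested is meant among the compounds shown, and "the series" means these compounds.

Compound 1 `CNC(=O)c1cc(C(=O)NC2CC2)cn(Cc2cccc(OC)c2)c1=O` sits second highest of the three measured numbers in a physicochemical assay for lipophilicity, at pH 7.4 (on this read-out lower numbers stand for lower lipophilicity and higher numbers for higher lipophilicity), where compound 1 gives 3. Compound 2 `CNC(=O)c1cc(C(=O)NC2CCC2)cn(Cc2ccccn2)c1=O` gives 2.2 in this assay, and compound 3 `CNC(=O)c1cc(C(=O)NC2CCC2)cn(Cc2ccccc2)c1=O` gives 3.8; compound 1 lies between them, its gap to either one beyond the scatter. Within the data shown here, the one measured step between single-change neighbours is a number 1.60 log units higher from compound 2 to compound 3 (beyond the scatter).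

Compound 4 `CNC(=O)c1cc(C(=O)NC2CC2)cn(Cc2cccc3cn[nH]c23)c1=O` differs from compound 1 in one place: 1H-indazol-7-yl in place of 3-methoxyphenyl on a saturated chain carbon bound to an aromatic nitrogen. This step bears on the measured one from compound 2 to compound 3 only in reverse: there, an all-carbon aromatic in place of one holding a ring nitrogen raised this assay sharply. Here a ring with two nitrogens and a hydrogen-bond donor enters where the methoxy-bearing all-carbon ring leaves, so the number is expected to fall beyond the scatter, though not as far as that earlier step. Compound 4 is therefore expected to give 2.2, between 1.6 and 2.8, a step of a number 0.80 log units lower from compound 1 to compound 4 (beyond the scatter).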

Compound 4, distribution coefficient: 2.2
Compound 4: middle estimate and measured number agree at the digits printed, within the range that was stated.
By their numbers in this assay, from the lowest: compounds 2 and 4 (each within the scatter of the next); then compound 1; then compound 3.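

At the place on a saturated chain carbon bound to an aromatic nitrogen, this assay also responds to a two-ring group: 1H-indazol-7-yl in place of 3-methoxyphenyl gives a number 0.80 log units lower from compound 1 to compound 4 (beyond the scatter) in this change. The earlier step, a number 1.60 log units higher from compound 2 to compound 3 (beyond the scatter), exchanged one single ring for another at this place, so the new step extends the sensitivity of the read-out at this place to a different group and to a compound that differs elsewhere as well. No measurement shown here accounts for the size of the new step.

Among these compounds, whether it follows from the five-membered aromatic ring, the hydrogen-bond donor or the loss of methoxy stays open, as these change together in the one step. A 3-hydroxyphenyl or 3-aminophenyl group at this place on the core of compound 1 would bear on that question.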